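The compounds below may be only part of what the source reports. "The series", "measured", "known", "first", "only" and "open" are said of these compounds alone.

Three compounds sharing one core have been measured in a functional assay on A549 cells (Homo sapiens) for cytotoxicity, read by sulforhodamine B assay; a higher number here means a weaker inhibitor, a lower number a stronger inhibitor:

Compound 1 `C=C1[C@@H](OC(C)=O)C[C@@H]2[C@](C)(CO[Si](C)(C)C(C)(C)C)[C@H](OC(C)=O)CC[C@@]2(C)[C@@H]1C[C@@H](Nc1ccccc1)C1=CCOC1=O` gives 4500 nM.
Compound 2 `C=C1[C@@H](OC(C)=O)C[C@@H]2[C@](C)(CO[Si](C)(C)C(C)(C)C)[C@H](OC(C)=O)CC[C@@]2(C)[C@@H]1C[C@@H](Nc1ccc(OC)cc1)C1=CCOC1=O` gives 4810 nM.
Compound 3 `C=C1[C@@H](OC(C)=O)C[C@@H]2[C@](C)(CO[Si](C)(C)C(C)(C)C)[C@H](OC(C)=O)CC[C@@]2(C)[C@@H]1C[C@@H](Nc1cccc(F)c1)C1=CCOC1=O` gives 4060 nM.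

All three carry the same core and differ only in the aromatic group on the amine nitrogen. Compound 3 shows the lowest of the three numbers, but the distances to the others are small: a 1.1-fold lower number from compound 1 to compound 3 (0.04 log units; within the scatter) and a 1.2-fold lower number from compound 2 to compound 3 (0.07 log units; within the scatter), so nothing separates it from compound 1 or compound 2 beyond the scatter. The remaining step, a 1.1-fold higher number from compound 1 to compound 2 (0.03 log units; within the scatter), is likewise within the scatter.

Compound 4 `C=C1[C@@H](OC(C)=O)C[C@@H]2[C@](C)(CO[Si](C)(C)C(C)(C)C)[C@H](OC(C)=O)CC[C@@]2(C)[C@@H]1C[C@@H](Nc1ccc(C(=O)O)cc1)C1=CCOC1=O` is the next step from compound 3. The change is 4-carboxyphenyl in place of 3-fluorophenyl on an amine nitrogen.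

For the measured compounds named here, every measured step so far has swapped the substituent on that same aromatic ring, and none moved the number beyond the scatter. Going by the values given here, the entering 4-carboxyphenyl brings a hydrogen-bond donor and acceptor that none of the measured groups carried, so the earlier steps only partly bear on it. Still, with nothing in the data pointing in either direction, the expectation is a step of a 1.4-fold higher number from compound 3 to compound 4 (0.13 log units; within the scatter), that is, no change beyond the scatter, with the range widened to allow for the new group.

Compound 4 is therefore estimated at 5500 nM, between 2500 nM and 12000 nM.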

Compound 4, half-maximal inhibitory concentration: 4210 nM
The estimate for compound 4 lay 1.3-fold (0.12 log units) above the measured number; the range from low to high includes it.
By their numbers in this assay, from the lowest: compounds 3, 4, 1 and 2 (each within the scatter of the next).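

In this assay, for the compounds shown here, the group on the amine nitrogen can change from 3-fluorophenyl to 4-carboxyphenyl, bringing in a hydrogen-bond donor and acceptor that no earlier compound carried, and the step is a 1.0-fold higher number from compound 3 to compound 4 (0.02 log units; within the scatter). The comparisons with the other two compounds agree, with a 1.1-fold lower number from compound 1 to compound 4 (0.03 log units; within the scatter) when carboxy takes the place of hydrogen and a 1.1-fold lower number from compound 2 to compound 4 (0.06 log units; within the scatter) when carboxy takes the place of methoxy, so across these four compounds this position accepts all the ring substituents shown without the number moving beyond the scatter. No experimental information is available here to explain this flat result.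

The compounds shown leave open whether an aminomethyl group on that aromatic ring, or a simple alkyl chain in place of the ring on the amine nitrogen, would move the number beyond the scatter. They also leave open how much the shared core contributes to the number, since all four compounds carry it unchanged and only the aromatic group on the amine nitrogen varies.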